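A few compounds are considered here, and "the series" means these few. Any claim that something is new, unique, unknown or untested is made for them only; others in the source may bear on it.

Of the compounds shown here, three sharing one core have been measured in an assay on isolated protein for agonist activity at Bile acid receptor (Homo sapiens), read by AlphaScreen, with a stated time of 1 h; a lower number here means that less compound is needed, a higher number that more compound is needed for the effect. Compound 1 `O=C1CCc2cc(OCc3c(-c4c(Cl)cccc4Cl)noc3C3CC3)ccc2N1c1ncc(O)cc1F` gives 9 nM. Compound 2 `O=C(O)c1cnc(N2C(=O)CCc3cc(OCc4c(-c5c(Cl)cccc5Cl)noc4C4CC4)ccc32)c(Cl)c1` gives 13 nM. Compound 3 `O=C(O)c1ccc(N2C(=O)CCc3cc(OCc4c(-c5c(Cl)cccc5Cl)noc4C4CC4)ccc32)nc1` gives 20 nM; it stands highest of the three numbers, with the gap to compound 2 within the scatter and the gap to compound 1 beyond it.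

Compound 4 `O=C(O)c1ccc(N2C(=O)CCc3cc(OCc4c(-c5c(Cl)cccc5Cl)noc4C4CC4)ccc32)cc1O` differs from compound 3 by 4-carboxy-3-hydroxyphenyl in place of 5-carboxypyridin-2-yl on an amide-type nitrogen in a ring. All three measured steps alter the same ring on this nitrogen: a 1.4-fold higher number from compound 1 to compound 2 (0.16 log units; within the scatter), a 2.2-fold higher number from compound 1 to compound 3 (0.35 log units; beyond the scatter) and a 1.5-fold higher number from compound 2 to compound 3 (0.19 log units; within the scatter). Every one of them was small, and two lay within the scatter, so the ring on the amide nitrogen has so far moved the number only modestly. Among the measured compounds shown here, the new ring carries a carboxylic acid as compound 2 and compound 3 do, but no measured step reports a pyridine swapped for a phenol, so the expectation is loose.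

For compound 4 a step of a 1.5-fold higher number from compound 3 to compound 4 (0.18 log units; within the scatter) is expected, with no clear direction beyond the scatter. Compound 4 is estimated at 30 nM, with a range from 10 nM to 90 nM.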

Compound 4, half-maximal effective concentration: 20 nM
Estimate against measurement, compound 4: 1.5-fold (0.18 log units) above; the range from low to high includes it.
By their numbers in this assay, from the lowest: compounds 1, 2, 3 and 4 (each within the scatter of the next, the first and the last beyond it).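

In this assay, the step from the pyridine ring to a ring of carbon only, which also carries a hydroxy group, gave no change at the digits printed from compound 3 to compound 4 (within the scatter), so at this place on the amide-type nitrogen a ring nitrogen was not required to keep the number. The new ring also stayed within the scatter of the chlorinated acid, with a 1.5-fold higher number from compound 2 to compound 4 (0.19 log units; within the scatter), whereas compound 4 kept a gap beyond the scatter to the acid-free compound 1, with a 2.2-fold higher number from compound 1 to compound 4 (0.35 log units; beyond the scatter). No supporting data bear on why these numbers sit so close together.

The compounds shown do not separate the part played by the hydroxy group from that of the ring change, which a plain 4-carboxyphenyl ring would address. As far as these compounds go, how a tetrazole in place of the carboxylic acid would read also remains open.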